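From tert-butyl to ethyl on compound 2

A few compounds are considered here, and "the series" means these few. Any claim that something is new, unique, unknown or untested is made for them only; others in the source may bear on it.

For the measured compounds named here, in an ADME assay on microsomes from liver (Mus musculus, strain CD1) for metabolic stability, read by HPLC, using NADPH, with a stated time of 30 min, tested at 0.5 uM (on this read-out lower numbers stand for slow clearance and higher numbers for fast clearance), compound 2 `CC(C)(C)[C@H]1CC[C@H](n2c(=O)[nH]c3ncc(N)cc3c2=O)CC1` gives 0.5 mL.min-1.g-1, the lowest of the three numbers so far. Compound 1 `CC(=O)Nc1cnc2[nH]c(=O)n([C@H]3CC[C@H](C(C)(C)C)CC3)c(=O)c2c1` stands at 1.4 mL.min-1.g-1 and compound 3 `CC(C)(C)[C@H]1CC[C@@H](n2c(=O)[nH]c3ncc(N)cc3c2=O)CC1` at 1.6 mL.min-1.g-1 on the same read-out. Removing the acetyl gave a 2.8-fold lower number from compound 1 to compound 2 (0.45 log units; beyond the scatter), and both of these steps lie beyond the scatter, as does a 3.2-fold higher number from compound 2 to compound 3 (0.51 log units; beyond the scatter) because of the fact that compounds 2 and 3 differ only in the configuration as drawn.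

Compound 4 `CC[C@H]1CC[C@H](n2c(=O)[nH]c3ncc(N)cc3c2=O)CC1` carries ethyl in place of tert-butyl on a saturated ring carbon. Neither measured step changes this group, so they show only the size of steps in this small set, both modest, and no direction for the new change. No step beyond the scatter is therefore expected in this assay, with a slight lean to a higher number since compound 2 at 0.5 mL.min-1.g-1 sits lowest of the three. The estimated move is a 1.4-fold higher number from compound 2 to compound 4 (0.15 log units; within the scatter). Compound 4 is expected at 0.7 mL.min-1.g-1, with an estimated range from 0.3 mL.min-1.g-1 to 1.6 mL.min-1.g-1.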

Compound 4, intrinsic clearance in microsomes: 0.9 mL.min-1.g-1
Compound 4: the middle estimate sits 1.3-fold (0.11 log units) below what was measured; the measured number falls inside the stated range.
By their numbers in this assay, from the lowest: compounds 2, 4, 1 and 3 (each within the scatter of the next, the first and the last beyond it).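

For the compounds shown here, the earlier steps left the tert-butyl group untouched, so this is the first reading of a change on this saturated ring carbon of the six-membered non-aromatic ring. In this assay, ethyl in place of tert-butyl gives a 1.8-fold higher number from compound 2 to compound 4 (0.26 log units; within the scatter), so at this position the smaller alkyl group leaves intrinsic clearance in microsomes indistinguishable from that of the tert-butyl compound, unlike the removal of the acetyl or the inversion of configuration, whose steps lie beyond the scatter. Nothing given here explains this result.

The compounds shown leave open whether a methyl group, a longer chain, a hydroxyl group or an amine on this ring carbon would stay equally close to compound 2. As far as these compounds go, it also remains open whether inverting the configuration of compound 4 would raise the number as it does for the tert-butyl pair.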